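This account rests on a few compounds, and the source may have more. Where it says the series, first, only, none or still open, it means among the compounds named here.

The three measured compounds share one core and differ only in the acyl group on the amide nitrogen. Compound 1, `C=C(C)C(=O)Nc1cccc(-c2nc3ccccc3s2)c1`, carries a 1-methylethenyl group on the carbonyl carbon; in an ADME assay on BJ cells (Homo sapiens) for inhibition, with a stated time of 72 h (a higher number here means that more compound is needed for the effect, a lower number that less compound is needed), compound 1 gives only the limit > 25000 nM. Compound 2, `O=C(O)/C=C/C(=O)Nc1cccc(-c2nc3ccccc3s2)c1`, carries a 2-carboxyethenyl group there; in this assay compound 2 likewise gives only the limit > 25000 nM. For the measured compounds named here, compound 3, `O=C(CCl)Nc1cccc(-c2nc3ccccc3s2)c1`, carries a chloromethyl group; in this assay compound 3 gives 8500 nM, the only number among the three. The steps of an at least 2.9-fold lower number from compound 1 to compound 3 (0.46 log units; beyond the scatter) and an at least 2.9-fold lower number from compound 2 to compound 3 (0.46 log units; beyond the scatter) both fall beyond the scatter, whereas the step that the two limits leave unreadable from compound 1 to compound 2 cannot be read against the limits, so compound 3 is the single measured point of the series.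

Compound 4, `CC(Cl)C(=O)Nc1cccc(-c2nc3ccccc3s2)c1`, differs from compound 3 by methyl in place of hydrogen on a saturated chain carbon bound to a carbonyl carbon and a chlorine atom. Going by the values given here, none of the measured steps alters a group at this position; they exchange the whole acyl group, and the two readable ones run toward compound 3. Because compound 3 gives 8500 nM with the chloromethyl group that compound 4 retains, the expected step of a 1.2-fold higher number from compound 3 to compound 4 (0.07 log units; within the scatter) is small and within the scatter. Compound 4 is therefore estimated at 10000 nM, with a range from 4000 nM to 25000 nM.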

Compound 4, half-maximal effective concentration: > 25000 nM
Compound 4: only a limit was reported; the forecaster's own chance of this, stated with the estimate: 25%; middle value at least 2.5-fold (0.39 log units) away from the limit.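

The change of hydrogen to methyl on a saturated chain carbon bound to a carbonyl carbon and a chlorine atom gives an at least 2.9-fold higher number from compound 3 to compound 4 (0.46 log units; beyond the scatter). Unlike the earlier steps, which exchange the whole acyl group, this one alters the chloromethyl group at a single place, and it shows that this one added carbon, with the chlorine atom retained, is enough for a change beyond the scatter. In this assay compound 4 gives only a limit, > 25000 nM, so the 1-chloroethyl group moves the series from its single number to that same limit: the limit of > 25000 nM in this assay, at which 3 of the 4 values shown sit.

On these data alone, the steps from compound 1 and from compound 2 to compound 4 cannot be read, as both ends are limits, and how far the number rises from compound 3 to compound 4 stays open. Also open, as far as these compounds go, is what an ethyl group, an amine or a longer chain on this saturated chain carbon would give in this assay, and whether the step from hydrogen to methyl would look the same with a bromine atom in place of the chlorine atom.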